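This account rests on a few compounds, and the source may have more. Where it says the series, first, only, none or still open, it means among the compounds named here.

Compound 1 `Cc1nn(C)c2c1C(c1cccc(Cl)c1)=NCCN2` and compound 2 `Cc1nn(C)c2c1C(c1cccc(Cl)c1)=NCCN2C` share one core; compound 2 carries methyl in place of hydrogen on a nitrogen on an aromatic ring in a ring. In a functional assay on the whole organism for positive allosteric modulation, with Rattus norvegicus as the target (a higher number here means that more compound is needed for the effect, a lower number that less compound is needed), compound 1 gives 0.63 mg/kg, and compound 2 gives 0.63 mg/kg; the step is no change at the digits printed from compound 1 to compound 2 (within the scatter). Compound 3 `Cc1nn(C)c2c1C(c1ccccc1Cl)=NCCN2` is built from the same atoms as compound 1, joined differently; the difference between the two cores is not broken down here. In this assay compound 3 gives 2.5 mg/kg, the highest of the three numbers, so more of compound 3 is needed than of compound 1 or compound 2.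

Compound 4 `Cc1nn(C)c2c1C(c1ccccc1Cl)=NCCN2C` is still to be measured in this assay. It stands to compound 3 as compound 2 stands to compound 1: methyl in place of hydrogen on a nitrogen on an aromatic ring in a ring, the same change, at a place described in identical terms on both cores. For the measured compounds named here, only one earlier instance of this change is known, so any expectation rests on a single pair. Because no change at the digits printed from compound 1 to compound 2 (within the scatter) shows no movement, the step from compound 3 to compound 4 is expected to be no change at the digits printed from compound 3 to compound 4 (within the scatter). Compound 4 is therefore estimated at 2.5 mg/kg, with a range from 1.25 mg/kg to 5 mg/kg, pending the measurement.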

Compound 4, minimum effective dose: 2.5 mg/kg
Beside the measured number, compound 4's estimate shows no gap at the digits printed; low and high end bracket the measured number.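

In this assay the methyl in place of hydrogen on a nitrogen on an aromatic ring in a ring gives no change at the digits printed from compound 3 to compound 4 (within the scatter), and the two cores agree on this step: the same change on two cores in this assay, no change at the digits printed (within the scatter) from compound 1 to compound 2 and no change at the digits printed (within the scatter) from compound 3 to compound 4, 1.0-fold (0.00 log units) apart, within the scatter of two such steps. For the compounds shown here, in this series, the change therefore carries from the core of compound 1 to the core of compound 3 without a visible shift in the minimum effective dose, although this rests on only two pairs. These pairs do not show that the step would stay flat on a further core, and they give no reason why the dose holds or any information on a read-out other than this whole-organism one.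

The compounds shown carry only hydrogen or methyl on this nitrogen, so it remains open whether ethyl, a longer chain ending in an amine, or a chain ending in a carboxylic acid would leave the dose equally unmoved. On these data alone, it also remains open whether the flat step would hold with fluorine in place of chlorine.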